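One More Fluoro on Compound 1

The source may report more compounds than this note shows. Statements on the series, on what has been measured and on what is new or still open speak of the compounds shown alone.

In a functional assay on HUVEC cells (Homo sapiens) for antiproliferative activity (on this read-out higher numbers stand for weaker inhibition and lower numbers for stronger inhibition), compound 1 (`CNC(=O)c1ccc(F)c(NCc2cnc(Nc3ccccn3)s2)c1`) gives 20 nM as its reading. Within the data shown here, only one neighbour has been measured so far: compound 2 (`O=C(NC1CC1)c1ccc(F)c(NCc2cnc(Nc3ccccn3)s2)c1`) gives 14 nM on the same read-out, so the two sit level within the scatter. Compound 3 (`CNC(=O)c1cc(NCc2cnc(Nc3ccccn3)s2)c(F)cc1F`) keeps the core of compound 1 but carries fluoro in place of hydrogen on an aromatic carbon. Among the measured compounds shown here, no measured step tests this kind of change. For the measured compounds named here, the sole measured step, a 1.4-fold lower number from compound 1 to compound 2 (0.15 log units; within the scatter), swaps methyl for cyclopropyl at a different place, so it offers only weak guidance. On this thin evidence, no step beyond the scatter is expected in this assay for the new fluoro. The expected step, no change at the digits printed from compound 1 to compound 3 (within the scatter), is an estimate only. For compound 3 the estimated value is 20 nM with an expected range from 7 nM to 60 nM as the likely spread.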

Compound 3, half-maximal inhibitory concentration: 52 nM
Estimate against measurement, compound 3: 2.6-fold (0.41 log units) below, within the range that was stated.
By their numbers in this assay, from the lowest: compounds 2 and 1 (each within the scatter of the next); then compound 3.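

In this assay, placing fluoro on the aromatic carbon ortho to a methylcarbamoyl group gives a 2.6-fold higher number from compound 1 to compound 3 (0.41 log units; beyond the scatter), a modest weakening of inhibition. Among these compounds, this is the first step that lies beyond the scatter, so this ring position is sensitive even to a single added fluoro, whereas the swap of methyl for cyclopropyl on the amide nitrogen left the reading within the scatter. No measurement of any kind is available to explain the weakening.

Going by these compounds, whether the weakening belongs to fluoro itself or would follow any group on this carbon stays open, and a chloro, methyl or methoxy group there would help to separate the two. Also open, on these data alone, is whether the cyclopropyl amide of compound 2 would respond to this fluoro in the same way.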